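Chloro for Nitro on the Pendant Phenyl Ring

This account rests on a few compounds, and the source may have more. Where it says the series, first, only, none or still open, it means among the compounds named here.

Compound 1 `COc1ccccc1C(C1=C(O)C(=O)c2ccccc2C1=O)c1c[nH]c2ccccc12`: in a toxicity assay (Homo sapiens) for cytotoxicity, read by MTT assay, with a stated time of 48 h (on this read-out lower numbers stand for stronger inhibition and higher numbers for weaker inhibition), compound 1 gives > 200000 nM, which is a limit of the assay.
Compound 2 `Cc1[nH]c2ccccc2c1C(C1=C(O)C(=O)c2ccccc2C1=O)c1ccc(Cl)cc1`: in this assay compound 2 gives 40300 nM.
Compound 3 `O=C1C(O)=C(C(c2ccc([N+](=O)[O-])cc2)c2c[nH]c3ccccc23)C(=O)c2ccccc21`: in this assay compound 3 gives > 200000 nM, again a limit of the assay.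

Compound 3 thus stands at the limit of > 200000 nM in this assay, at which 2 of the 3 values shown sit. Within the data shown here, the only single-point step among the measured compounds, a step that the two limits leave unreadable from compound 1 to compound 3, offers no readable size, as both of its ends are limits. Compound 4 `O=C1C(O)=C(C(c2ccc(Cl)cc2)c2c[nH]c3ccccc23)C(=O)c2ccccc21` differs from compound 3 by chloro in place of nitro on an aromatic carbon. Among the measured compounds shown here, no measured step bears directly on this change. For the measured compounds named here, compound 2, which also carries a 4-chlorophenyl group but adds a methyl on its indole ring, registers a number rather than a limit; it differs from compound 4 in two places, so it shows only that a 4-chlorophenyl member of this core can fall within the assay window. For compound 4 the expected step of an at least 1.6-fold lower number from compound 3 to compound 4 (0.22 log units; that floor lies within the scatter) is therefore uncertain and could be none at all. Compound 4 is estimated at 120000 nM, with a range from 30000 nM to 200000 nM.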

Compound 4, half-maximal inhibitory concentration: 102000 nM
Estimate against measurement, compound 4: 1.2-fold (0.07 log units) above; measured number inside the range.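

Chloro in place of nitro brings the core of compound 3 into the measurable range in this assay, with an at least 1.9-fold lower number from compound 3 to compound 4 (0.29 log units; that floor lies within the scatter) and, for 4-chlorophenyl in place of 2-methoxyphenyl, with an at least 1.9-fold lower number from compound 1 to compound 4 (0.29 log units; that floor lies within the scatter) as the matching step. Among these compounds, the methyl group now has a readable size: hydrogen in place of methyl on an aromatic carbon gives a 2.5-fold higher number from compound 2 to compound 4 (0.40 log units; beyond the scatter) and is the only new step beyond the scatter. Compound 1 and compound 3 remain limits of the assay: the limit of > 200000 nM in this assay, at which 2 of the 4 values shown sit.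

As far as these compounds go, whether an amine or a carboxylic acid in place of chloro on that aromatic carbon would give a number in this assay stays open, as does the full size of the step from nitro to chloro. Also open, from the compounds shown here alone, is whether the methyl step would read the same with 4-nitrophenyl in place of 4-chlorophenyl.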